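Acetamido for methyl on the aryl ring of compound 3

A few compounds are considered here, and "the series" means these few. Any claim that something is new, unique, unknown or untested is made for them only; others in the source may bear on it.

Measured in a functional assay on NCI-H460 cells (Homo sapiens) for antiproliferative activity, with a stated time of 72 h (on this read-out lower numbers stand for stronger inhibition and higher numbers for weaker inhibition), so far:
- Compound 1, `C=CC[C@@H]1C[C@]2([C@H](C)Cc3ccc(OC)c(OC)c3)OCOC2=CC1=O`: compound 1 reaches only the assay limit, > 4000 nM.
- Compound 2, `C=CC[C@H]1C[C@]2([C@@H](C)Cc3ccccc3)OCOC2=CC1=O`: compound 2 gives 9700 nM.
- Compound 3, `C=CC[C@H]1C[C@]2([C@@H](C)Cc3ccc(OC)c(C)c3)OCOC2=CC1=O`: compound 3 gives 630 nM.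

Compound 3 holds the lowest of the two numbers; compound 2 sits well above it, beyond the scatter. Compound 1 contributes no number, only a limit (the limit of > 4000 nM in this assay, at which 1 of the 3 values shown sits).

Compound 4, `C=CC[C@H]1C[C@]2([C@@H](C)Cc3ccc(OC)c(NC(C)=O)c3)OCOC2=CC1=O`, is the next entry: acetamido in place of methyl on an aromatic carbon. Going by the values given here, no measured pair traces this exchange, so the expected step from compound 3 to compound 4, a 2.4-fold higher number from compound 3 to compound 4 (0.38 log units; beyond the scatter), is placed modestly toward higher numbers, possibly no further than the scatter. Compound 4 is therefore estimated at 1500 nM, within 400 nM to 6000 nM.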

Compound 4, half-maximal inhibitory concentration: 310 nM
Compound 4: middle estimate off by 4.8-fold (0.68 log units), on the high side; measured number below the stated range.
By their numbers in this assay, from the lowest: compound 4; then compound 3; then compound 2.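

At this aromatic carbon, ortho to a methoxy group, the larger acetamido group takes the place of methyl without any loss in this assay: the change gives a 2.0-fold lower number from compound 3 to compound 4 (0.31 log units; beyond the scatter). The position therefore accepts more than a methyl, including a group carrying a hydrogen-bond donor and acceptor. Nothing measured here accounts for the step.

Still open, as far as these compounds go, is whether an amine, a hydroxyl or a longer acyl chain at this carbon would hold the gain. The part played by the amide hydrogen also remains unresolved.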